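The compounds below may be only part of what the source reports. "The series", "measured", "known", "first", "only" and "open" are said of these compounds alone.

For the measured compounds named here, in a functional assay on MV4-11 cells (Homo sapiens) for antiproliferative activity, read by CellTiter-Glo, with a stated time of 72 h (a higher number here means a weaker inhibitor of growth, a lower number a stronger inhibitor of growth), compound 2, `CNc1nc(-c2cc(N[C@H]3CC[C@H](NCCOC)CC3)ncc2Cl)cs1`, gives 530 nM, the only true number so far. Compound 1, `O=C(N[C@H]1CC[C@H](Nc2cc(-c3csc(NCC4CCOCC4)n3)c(Cl)cn2)CC1)C1CC1`, reads > 10000 nM in this assay, which is a limit and not a number. Compound 3, `COCCN[C@H]1CC[C@H](Nc2cc(-c3csc(NCC4CCCCC4)n3)c(Cl)cn2)CC1`, departs from compound 2 by cyclohexyl in place of hydrogen on a saturated chain carbon bound to a nitrogen on an aromatic ring, which turns methylamino into (cyclohexylmethyl)amino. Going by the values given here, no measured step covers this change, and compound 1 differs from compound 3 in more than one place, so it does not settle the direction. A moderate gain in growth inhibition is tentatively expected, a 2.7-fold lower number from compound 2 to compound 3 (0.42 log units; beyond the scatter). The estimate for compound 3 is 200 nM, with an expected range of 30 nM to 1500 nM.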

Compound 3, concentration for 50% growth inhibition: 820 nM
Beside the measured number, compound 3's estimate is 4.1-fold (0.61 log units) below it; low and high end bracket the measured number.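

In this assay, cyclohexyl in place of hydrogen on a saturated chain carbon bound to a nitrogen on an aromatic ring gives a 1.5-fold higher number from compound 2 to compound 3 (0.19 log units; within the scatter) for this change. Methylamino and (cyclohexylmethyl)amino therefore read alike here, so this position tolerates the added 6 heavy atoms without a shift beyond the scatter. Nothing shown gives a cause for this step.

Still open, as far as these compounds go, is whether phenyl in place of cyclohexyl would read alike. The same applies to a cyclohexyl carrying an amine or a carboxylic acid.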